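Replacing a Nitro Group with Hydroxy on a Benzyl Arm

The source may report more compounds than this note shows. Statements on the series, on what has been measured and on what is new or still open speak of the compounds shown alone.

Measured compounds:
Compound 1 `C/C=C/C(=O)N(Cc1ccc(OC)c([N+](=O)[O-])c1)c1cc(OC)c(OC)c(OC)c1`: 670 nM
Compound 2 `COc1ccc(CN(C(=O)C=C(C)C)c2cc(OC)c(OC)c(OC)c2)cc1O`: 290 nM
Compound 3 `CC/C=C/C(=O)N(Cc1ccc(OC)c(O)c1)c1cc(OC)c(OC)c(OC)c1`: 63 nM

In a functional assay on HCT-116 cells (Homo sapiens) for inhibition, read by MTT assay, with a stated time of 48 h (on this read-out lower numbers stand for stronger inhibition and higher numbers for weaker inhibition), compound 1 gives 670 nM, the highest number of the three measured compounds; compound 2 gives 290 nM, and compound 3 gives the lowest number at 63 nM. For the measured compounds named here, compounds 2 and 3 both carry a hydroxy group on the benzyl arm, and the single step between them concerns only the chain on the carbonyl carbon: a 4.6-fold lower number from compound 2 to compound 3 (0.66 log units; beyond the scatter).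

Compound 4 `C/C=C/C(=O)N(Cc1ccc(OC)c(O)c1)c1cc(OC)c(OC)c(OC)c1` is not yet measured. It differs from compound 1 in one place: hydroxy in place of nitro on an aromatic carbon. Going by the values given here, no measured pair shows this exact exchange, so its effect cannot be read off directly. Among the compounds with values here, what the data do show is that both compounds bearing the hydroxy group, compound 2 and compound 3, give lower numbers than compound 1, which is the only compound with a nitro group. On that basis compound 4 is expected to give a lower number than compound 1, with the step estimated as a 4.5-fold lower number from compound 1 to compound 4 (0.65 log units; beyond the scatter). The estimate for compound 4 is 150 nM, within a range from 50 nM to 500 nM, placing it among the two hydroxy-bearing compounds rather than beside compound 1.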

Compound 4, half-maximal inhibitory concentration: 55 nM
Compound 4: the middle estimate sits 2.7-fold (0.44 log units) above what was measured; low and high end bracket the measured number.
By their numbers in this assay, from the lowest: compounds 4 and 3 (each within the scatter of the next); then compound 2; then compound 1.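

In this assay, the exchange of nitro for hydroxy on this aromatic carbon, ortho to a methoxy group, can now be read directly, and with the rest of the structure unchanged it gives a 12-fold lower number from compound 1 to compound 4 (1.09 log units; beyond the scatter), so this position responds strongly to this change. The new compound also sharpens the picture of the chain on the carbonyl carbon when hydroxy is present: prop-1-en-1-yl and but-1-en-1-yl cannot be told apart, with a 1.1-fold lower number from compound 3 to compound 4 (0.06 log units; within the scatter), whereas prop-1-en-1-yl in place of 2-methylprop-1-en-1-yl gives a 5.3-fold lower number from compound 2 to compound 4 (0.72 log units; beyond the scatter). Nothing available explains why the exchange of nitro for hydroxy has so large an effect.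

From the compounds shown here alone, the nitro-to-hydroxy step is seen with only one chain, prop-1-en-1-yl, so its size with but-1-en-1-yl or 2-methylprop-1-en-1-yl stays open. Also open, going by these compounds, is how an amine or a carboxylic acid on the same aromatic carbon would compare with hydroxy, and whether a longer chain on the carbonyl carbon would keep the number near that of compound 3 and compound 4.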